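Hydroxy in Place of Methyl on the Shared Core

This account rests on a few compounds, and the source may have more. Where it says the series, first, only, none or still open, it means among the compounds named here.

The three measured compounds, with their numbers in a functional assay on PC-3 cells (Homo sapiens) for antiproliferative activity, read by XTT assay; on this read-out higher numbers stand for weaker inhibition and lower numbers for stronger inhibition:
compound 1 `O=c1c(Cc2coc3cccc(OCC4CCCCC4)c3c2=O)coc2ccccc12` gives 4510 nM
compound 2 `COc1ccc2c(=O)c(Cc3coc4cccc(OCC5CCCCC5)c4c3=O)coc2c1` gives 1120 nM
compound 3 `Cc1ccc2c(=O)c(Cc3coc4cccc(OCC5CCCCC5)c4c3=O)coc2c1` gives 2440 nM

Compound 3 stands second highest of these three numbers. Its step from the unsubstituted parent is small: a 1.8-fold lower number from compound 1 to compound 3 (0.27 log units; within the scatter). Against compound 2 the gap is larger: a 2.2-fold higher number from compound 2 to compound 3 (0.34 log units; beyond the scatter), so the methyl sits between hydrogen and methoxy on this read-out.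

Compound 4 `O=c1c(Cc2coc3cccc(OCC4CCCCC4)c3c2=O)coc2cc(O)ccc12` is the next step from compound 3: hydroxy in place of methyl on an aromatic carbon. For the measured compounds named here, two measured steps bear on it. The methoxy step, a 4.0-fold lower number from compound 1 to compound 2 (0.60 log units; beyond the scatter), is the only one beyond the scatter that lowered the number, and the hydroxy entering here carries an oxygen as methoxy does; the methyl step, a 1.8-fold lower number from compound 1 to compound 3 (0.27 log units; within the scatter), stayed within the scatter. On that basis a modest lowering in this assay is expected for compound 4, roughly a 1.6-fold lower number from compound 3 to compound 4 (0.21 log units; within the scatter), though a result within the scatter cannot be excluded. The estimate for compound 4 in this assay is 1500 nM, with a range from 600 nM to 4000 nM.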

Compound 4, half-maximal inhibitory concentration: 4250 nM
The estimate for compound 4 lay 2.8-fold (0.45 log units) below the measured number; the measured number lies above the stated range.
By their numbers in this assay, from the lowest: compound 2; then compounds 3, 4 and 1 (each within the scatter of the next).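

At this position, an oxygen on the aromatic carbon does not by itself bring the lowering seen with methoxy in this assay: taking the methyl off that oxygen gives a 3.8-fold higher number from compound 2 to compound 4 (0.58 log units; beyond the scatter). Hydroxy cannot be told apart from hydrogen here, with a 1.1-fold lower number from compound 1 to compound 4 (0.03 log units; within the scatter), nor from methyl, with a 1.7-fold higher number from compound 3 to compound 4 (0.24 log units; within the scatter). Among these four compounds, only compound 2 is separated from all the others by steps beyond the scatter, so the methoxy group stands alone at this place.

As far as these compounds go, whether a longer ether such as ethoxy would behave as methoxy does, and whether an amine or a fluorine here would side with methoxy or with hydroxy, remains open. Nothing given here accounts for the gap between methoxy and hydroxy.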